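The compounds below may be only part of what the source reports. "The series", "measured", "known", "first", "only" and "open" are said of these compounds alone.

Measured so far:
- compound 1 (`Cc1cc(=O)c2c(O)cc(OCc3ccccc3)c([C@H]3CCN(C)C[C@H]3O)c2o1`) gives 14%
- compound 2 (`CCN(CC)Cc1c(O)c([C@H]2CCN(C)C[C@H]2O)c2oc(C)cc(=O)c2c1O`) gives 27%

Both values come from a functional assay on MIA PaCa-2 cells (Homo sapiens) for inhibition, read by MTT assay, with a stated time of 48 h, tested at 10 uM; a lower number here means less inhibition of growth, a higher number more inhibition of growth at the concentration tested. Compound 2 stands higher of the two, and its gap to compound 1 lies beyond the scatter. Compound 3 (`Cc1cc(=O)c2c(O)c(CN3CCCC3CO)c(O)c([C@H]3CCN(C)C[C@H]3O)c2o1`) differs from compound 2 as follows: 2-(hydroxymethyl)pyrrolidin-1-yl in place of diethylamino on a saturated chain carbon bound to an aromatic carbon. Among the measured compounds shown here, no measured pair shows this change, so no step beyond the scatter is expected in this assay and the direction stays open. The estimated step is small (a number 2 percentage points lower from compound 2 to compound 3 (within the scatter)) and stays within the scatter. For compound 3 the expected value is 25% (estimated range 10% to 45%) in this read-out.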

Compound 3, percent growth inhibition at one concentration: 13%
Beside the measured number, compound 3's estimate is 12 percentage points above it; measured number inside the range.
By their numbers in this assay, from the lowest: compounds 3 and 1 (each within the scatter of the next); then compound 2.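

In this assay the place on a saturated chain carbon bound to an aromatic carbon responds to the group it carries, with 2-(hydroxymethyl)pyrrolidin-1-yl in place of diethylamino giving a number 14 percentage points lower from compound 2 to compound 3 (beyond the scatter) as the first step read at this place. No measurement available here bears on the cause of this step.

From the compounds shown here alone, since the ring and the hydroxymethyl enter together, their separate shares in the step remain open. Plain pyrrolidin-1-yl or morpholin-4-yl at this place would help to separate them.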